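Replacing a difluorophenyl group with a methylphenyl group

This account rests on a few compounds, and the source may have more. Where it says the series, first, only, none or still open, it means among the compounds named here.

Of the compounds shown here, three have been measured in a functional assay on NCI-H460 cells (Homo sapiens) for antiproliferative activity, with a stated time of 72 h (on this read-out higher numbers stand for weaker inhibition and lower numbers for stronger inhibition), so far.

- compound 1 `CCCC#Cc1cc([C@@H]2O[C@H](CO)[C@@H](O)[C@H]2O)n2ncnc(N)c12` gives 400 nM
- compound 2 `Nc1ncnn2c([C@@H]3O[C@H](CO)[C@@H](O)[C@H]3O)cc(C#Cc3cccs3)c12` gives 26600 nM
- compound 3 `Nc1ncnn2c([C@@H]3O[C@H](CO)[C@@H](O)[C@H]3O)cc(-c3ccc(F)cc3F)c12` gives 93300 nM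

Compound 3 has the highest number of the three and is the weakest inhibitor among them. Compound 4 `Cc1ccccc1-c1cc([C@@H]2O[C@H](CO)[C@@H](O)[C@H]2O)n2ncnc(N)c12` differs from it in one place, with 2-methylphenyl in place of 2,4-difluorophenyl on an aromatic carbon of the shared core (2-methylphenyl in place of 2,4-difluorophenyl on an aromatic carbon). Within the data shown here, no measured step exchanges one phenyl group for another. The nearest is the modest step (a 3.5-fold higher number from compound 2 to compound 3 (0.55 log units; beyond the scatter)), which removes 2-(thiophen-2-yl)ethynyl. The large steps (a 67-fold higher number from compound 1 to compound 2 (1.82 log units; beyond the scatter)) and (a 230-fold higher number from compound 1 to compound 3 (2.37 log units; beyond the scatter)) both alter the pent-1-yn-1-yl group, which compound 4 does not carry. A modest step toward a lower number is therefore expected in this assay (estimated as a 2.3-fold lower number from compound 3 to compound 4 (0.37 log units; beyond the scatter)). For compound 4 the estimated value is 40000 nM (expected range 10000 nM to 130000 nM).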

Compound 4, half-maximal inhibitory concentration: > 100000 nM
Compound 4: only a limit was reported (the forecaster's own chance of this, stated with the estimate: 15%); middle value at least 2.5-fold (0.39 log units) from the limit.
By their numbers in this assay, from the lowest: compound 1; then compound 2; then compound 3. At a limit, above all of these: compound 4.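

Compound 4 gives only a limit in this assay, not a number: the limit of > 100000 nM in this assay, at which 1 of the 4 values shown sits. A second substituted phenyl group on this aromatic carbon also gives a higher number than the alkyne-bearing compounds, with an at least 3.7-fold higher number from compound 2 to compound 4 (0.57 log units; beyond the scatter) and an at least 250-fold higher number from compound 1 to compound 4 (2.39 log units; beyond the scatter). The exchange of 2,4-difluorophenyl for 2-methylphenyl gives only a floor, an at least 1.0-fold higher number from compound 3 to compound 4 (0.03 log units; that floor lies within the scatter), so 2-methylphenyl and 2,4-difluorophenyl cannot be ordered, but neither comes near compound 1 with its pent-1-yn-1-yl group.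

From the compounds shown here alone, it remains open how far compound 4 actually lies beyond compound 3. Going by these compounds, it is also open whether a longer alkyne chain such as hex-1-yn-1-yl, or an amine on this carbon, would give a lower number than pent-1-yn-1-yl.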